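Adding an amino group where compound 2 proved inactive

The source may report more compounds than this note shows. Statements on the series, on what has been measured and on what is new or still open speak of the compounds shown alone.

Of the compounds shown here, two have been tested in a functional assay on HepG2 cells (Homo sapiens) for cytotoxicity, read by sulforhodamine B assay, with a stated time of 48 h; a lower number here means a stronger inhibitor, a higher number a weaker inhibitor. The first, compound 1 `C/C(=N\NC(=O)CC#N)c1ccc(NS(=O)(=O)c2ccccc2)cc1`, gives a half-maximal inhibitory concentration of 28000 nM in this assay. The second, compound 2 `Cc1ccc(S(=O)(=O)Nc2ccc(-c3cc(-c4ccc([N+](=O)[O-])cc4)n(C(N)=S)n3)cc2)cc1`, shares nothing of that scaffold and is recorded in this assay as "not active" (no number reported), so no number exists that would place it above or below compound 1.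

Compound 3 `Cc1ccc(S(=O)(=O)Nc2ccc(-c3cc(-c4ccc([N+](=O)[O-])cc4)n(C(=S)NN)n3)cc2)cc1` differs from compound 2 in one place: amino in place of hydrogen on an amide-type nitrogen. Among the compounds with values here, no measured pair shows what such a change does in this assay, so the direction of the step is unknown. Since compound 2 gave no measurable activity, the most likely outcome is that compound 3 also falls at or beyond the edge of what this assay can report, with a small chance of weak activity.

On that basis the half-maximal inhibitory concentration of compound 3 is estimated at 50000 nM, expected to lie between 15000 nM and 200000 nM.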

Compound 3, half-maximal inhibitory concentration: 45300 nM
For compound 3 the middle estimate is 1.1-fold (0.04 log units) above the measured one; the measured number falls inside the stated range.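

Within the data shown here, compound 2 carries no number in this assay, so no step from it to compound 3, at 45300 nM, can be read. Nothing shown here offers an explanation for this value. On these data alone, what the amino group changes in this assay stays open.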